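A few compounds are considered here, and "the series" means these few. Any claim that something is new, unique, unknown or untested is made for them only; others in the source may bear on it.

Working notes on the series. Compound 1 `Cc1nc2c3ccccc3ccc2c2nc3c(ccc4ccccc43)c(-c3cccc([N+](=O)[O-])c3)c12` carries a 3-nitrophenyl group on the shared core; in a functional assay on HCT-116 cells (Homo sapiens) for cytotoxicity, read by MTT assay, with a stated time of 48 h (on this read-out lower numbers stand for stronger inhibition and higher numbers for weaker inhibition), compound 1 gives 13200 nM. Compound 2 `Cc1nc2c3ccccc3ccc2c2nc3c(ccc4ccccc43)c(-c3cc([N+](=O)[O-])ccc3N)c12` adds an amino group to that ring, and in this assay compound 2 gives 6010 nM, a change of a 2.2-fold lower number from compound 1 to compound 2 (0.34 log units; beyond the scatter). Compound 3 `Cc1nc2c3ccccc3ccc2c2nc3c(ccc4ccccc43)c(-c3ccccc3Cl)c12` bears a 2-chlorophenyl group instead; in this assay compound 3 gives 48200 nM, which is the highest of the three numbers, reached by a 3.7-fold higher number from compound 1 to compound 3 (0.56 log units; beyond the scatter) and by an 8.0-fold higher number from compound 2 to compound 3 (0.90 log units; beyond the scatter).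

Compound 4 `Cc1nc2c3ccccc3ccc2c2nc3c(ccc4ccccc43)c(C)c12` differs from compound 3 in a single place: methyl in place of 2-chlorophenyl on an aromatic carbon. The two steps that bear on this position, a 3.7-fold higher number from compound 1 to compound 3 (0.56 log units; beyond the scatter) and an 8.0-fold higher number from compound 2 to compound 3 (0.90 log units; beyond the scatter), only exchange one aromatic group for another and both move the number upward toward compound 3. Among the measured compounds shown here, no measured step removes the aromatic ring altogether, so the direction of this change is not anchored by any pair in the set; the two steps at this place show that it is sensitive to what stands there, and movement beyond the scatter in either direction is plausible.

For compound 4 the estimate in this assay is 40000 nM, with a range from 10000 nM to 160000 nM, which corresponds to an expected step of a 1.2-fold lower number from compound 3 to compound 4 (0.08 log units; within the scatter).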

Compound 4, half-maximal inhibitory concentration: > 80000 nM
Compound 4 gave a limit, no number; the forecaster's own chance of this, stated with the estimate: 15%; middle value at least 2.0-fold (0.30 log units) from the limit.
By their numbers in this assay, from the lowest: compound 2; then compound 1; then compound 3. At a limit, above all of these: compound 4.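

In this assay compound 4 gives > 80000 nM, which is a limit of the assay and not a number. Taking the aromatic ring away from this carbon, opposite the ring nitrogen, and leaving methyl gives two steps well beyond the scatter, an at least 13-fold higher number from compound 2 to compound 4 (1.12 log units; beyond the scatter) and an at least 6.0-fold higher number from compound 1 to compound 4 (0.78 log units; beyond the scatter), so the first measured loss of the ring goes with a weaker read-out against both nitro-bearing compounds. Among the compounds shown here, compound 3 goes against any general claim for an aromatic ring here, since an at least 1.6-fold higher number from compound 3 to compound 4 (0.22 log units; that floor lies within the scatter) has a floor that does not separate methyl from 2-chlorophenyl, and the earlier steps, which only exchanged one aromatic group for another, could not show this split.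

The compounds shown leave open how much of the gain belongs to the ring itself and how much to the nitro and amino groups on it, a question that an unsubstituted phenyl or a 3-aminophenyl would bear on. They also leave open whether a saturated group such as cyclohexyl or a longer chain such as n-butyl at this carbon stays as weak as methyl.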